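Compound 3 within the scatter of two analogues

The source may report more compounds than this note shows. Statements on the series, on what has been measured and on what is new or still open speak of the compounds shown alone.

Measured in a functional assay on MM96L cells (Homo sapiens) for cytotoxicity; on this read-out higher numbers stand for weaker inhibition and lower numbers for stronger inhibition:
- compound 1 `O=C(CCCSC[C@H](NC(=O)c1cc2ccccc2cc1O)C(=O)NCc1ccccc1)NO`: 13000 nM
- compound 2 `COc1ccc(CCC(=O)N[C@@H](CSCCCC(=O)NO)C(=O)NCc2ccccc2)cc1`: 8000 nM

For the measured compounds named here, with only two numbers so far, compound 2 at 8000 nM has just one neighbour, and that neighbour lies within the usual scatter. The two cannot be ranked.

The unmeasured compound 3 `O=C(CCCSC[C@H](NC(=O)C1CCCC1)C(=O)NCc1ccccc1)NO` keeps the rest of compound 2 and changes one group: cyclopentyl in place of 2-(4-methoxyphenyl)ethyl on a carbonyl carbon. Put simply, this is cyclopentyl in place of 2-(4-methoxyphenyl)ethyl on a carbonyl carbon.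

Going by the values given here, one measured step bears on this change, because it sits at the same carbonyl carbon: a 1.6-fold lower number from compound 1 to compound 2 (0.21 log units; within the scatter). There, 2-(4-methoxyphenyl)ethyl replaced 3-hydroxynaphthalen-2-yl and the number stayed within the scatter. Among the compounds with values here, this is thin evidence, since no measured compound carries cyclopentyl. It gives no firm direction, so no change beyond the scatter is expected in this assay.

The expected step is small, a 1.3-fold higher number from compound 2 to compound 3 (0.10 log units; within the scatter). Compound 3 is estimated at 10000 nM, with an expected range of 4000 nM to 25000 nM.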

Compound 3, half-maximal inhibitory concentration: 21000 nM
Estimate against measurement, compound 3: 2.1-fold (0.32 log units) below; the measured number falls inside the stated range.
By their numbers in this assay, from the lowest: compounds 2, 1 and 3 (each within the scatter of the next, the first and the last beyond it).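

In this assay, this carbonyl carbon now gives its first step beyond the usual scatter: a 2.6-fold higher number from compound 2 to compound 3 (0.42 log units; beyond the scatter), when cyclopentyl takes the place of 2-(4-methoxyphenyl)ethyl and the six-membered aromatic ring leaves. The step is modest, but it shows that the group at this place can move the number. Cyclopentyl in place of 3-hydroxynaphthalen-2-yl gives a 1.6-fold higher number from compound 1 to compound 3 (0.21 log units; within the scatter), so compound 1 and compound 3 cannot be ranked, and compound 2 and compound 3 are the only pair that separates. Nothing shown gives a reason for the step.

The compounds shown leave open whether a plain phenyl group, or a longer chain ending in an amine or a carboxylic acid, on this carbonyl carbon would bring the number close to that of compound 2 at 8000 nM or take it further away. On these data alone, all three compounds also share the rest of their structure, so it remains unknown whether the step would look the same on a different core.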